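Methyl in Place of Bromo on the Aromatic Ring

This account rests on a few compounds, and the source may have more. Where it says the series, first, only, none or still open, it means among the compounds named here.

In a toxicity assay on the whole organism (strain Icem-CET (SPF Caw)) for cytotoxicity, with Mus musculus as the target (a lower number here means that less compound is needed, a higher number that more compound is needed for the effect), compound 2 `C/C(C(=O)NC1CC1)=C(/C)c1ccc(Br)cc1` gives 130 mg/kg, the lowest of the three numbers measured. Compound 3 `C#CCNC(=O)/C(C)=C(\C)c1ccc(OC)cc1` gives 150 mg/kg, which lies within the scatter of compound 2. Compound 1 `C=CCNC(=O)/C(C)=C(\C)c1ccc(Br)cc1` gives 500 mg/kg; the step of a 3.8-fold lower number from compound 1 to compound 2 (0.59 log units; beyond the scatter) came with cyclopropyl in place of allyl on an amide-type nitrogen. Compound 4 `C/C(C(=O)NC1CC1)=C(/C)c1ccc(C)cc1` differs from compound 2 by methyl in place of bromo on an aromatic carbon. That sole measured step concerned the nitrogen, not the aromatic ring, so it does not bear on this change, and compound 3 differs from compound 2 in two places at once. Compound 4 is therefore expected to show no step beyond the scatter, a 1.2-fold higher number from compound 2 to compound 4 (0.06 log units; within the scatter). Compound 4 is estimated at 150 mg/kg, within a range from 60 mg/kg to 400 mg/kg.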

Compound 4, dose for half-maximal effect: 150 mg/kg
The estimate for compound 4 equals the measured number at the digits printed, and the stated range covers the measured number.
By their numbers in this assay, from the lowest: compounds 2, 3 and 4 (each within the scatter of the next); then compound 1.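

The aromatic ring now has its own measured step: in this assay, methyl in place of bromo on an aromatic carbon, para to a large group, gives a 1.2-fold higher number from compound 2 to compound 4 (0.06 log units; within the scatter) here. With cyclopropyl kept on the amide-type nitrogen, this exchange stays within the scatter, unlike the earlier step at that nitrogen. Nothing available explains this result here. Going by these compounds, whether an amine or a carboxylic acid at this ring position would also stay within the scatter remains open. So does whether methyl and bromo would match with allyl on the nitrogen.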